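The source may report more compounds than this note shows. Statements on the series, on what has been measured and on what is new or still open speak of the compounds shown alone.

Measured compounds in an ADME assay on HEK-293T cells (Homo sapiens) for cytotoxicity, read by MTT assay, with a stated time of 72 h; a lower number here means a stronger inhibitor, a higher number a weaker inhibitor:

Compound 1, `O=C(Nc1nc2ccccc2s1)c1cn(-c2ccccc2)nc1-c1ccc(F)cc1` — 33400 nM
Compound 2, `O=C(Nc1nc2ccc(F)cc2s1)c1cn(-c2ccccc2)nc1-c1ccc(F)cc1` — 16700 nM
Compound 3, `Cc1ccc2nc(NC(=O)c3cn(-c4ccccc4)nc3-c3ccc(F)cc3)sc2c1` — > 50000 nM

Compound 2 gives the lowest of the two numbers in this assay. Its nearest neighbour is compound 1, and the step of a 2.0-fold lower number from compound 1 to compound 2 (0.30 log units; within the scatter) is within the scatter, so the two are not ordered. For compound 3 the assay reports only a limit, (the limit of > 50000 nM in this assay, at which 1 of the 3 values shown sits).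

Compound 4, `COc1ccc(-c2nn(-c3ccccc3)cc2C(=O)Nc2nc3ccc(F)cc3s2)cc1`, differs from compound 2 in one place: methoxy in place of fluoro on an aromatic carbon. Going by the values given here, two measured steps bear on it. The step of a 2.0-fold lower number from compound 1 to compound 2 (0.30 log units; within the scatter) lies within the scatter. The step of an at least 2.9-fold higher number from compound 2 to compound 3 (0.47 log units; beyond the scatter) goes beyond it, and there the number rose to a limit. Both of these steps alter a different part of the shared core than the change from compound 2 to compound 4, which sits on the 4-fluorophenyl ring. Removing a fluoro has so far raised the number, so a rise is the more likely direction, but on a different ring a modest step is the most that the data support.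

Compound 4 is therefore expected to give 30000 nM in this assay, between 12000 nM and 80000 nM. The expected step is a 1.8-fold higher number from compound 2 to compound 4 (0.25 log units; within the scatter).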

Compound 4, half-maximal inhibitory concentration: 15400 nM
For compound 4 the middle estimate is 1.9-fold (0.29 log units) above the measured one; the range from low to high includes it.
By their numbers in this assay, from the lowest: compounds 4, 2 and 1 (each within the scatter of the next, the first and the last beyond it). At a limit, above all of these: compound 3.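

In this assay, the change from 4-fluorophenyl to 4-methoxyphenyl gives a 1.1-fold lower number from compound 2 to compound 4 (0.04 log units; within the scatter), so compound 2 and compound 4 are not ordered. This is the only step shown on this ring, and it shows that at this place, para to a large group, methoxy with its two heavy atoms and one hydrogen-bond acceptor can stand in place of fluoro without a change beyond the scatter, whereas the earlier steps all altered a different part of the shared core, including the one step beyond the scatter, an at least 2.9-fold higher number from compound 2 to compound 3 (0.47 log units; beyond the scatter). Nothing in the data shown gives a reason for this flat step.

The compounds shown leave open whether this tolerance extends to other groups at the same place, such as an amine, a carboxylic acid or a longer alkoxy chain like butoxy. Also open, from the compounds shown here alone, is how the 4-methoxyphenyl ring behaves alongside the methyl group of compound 3, whose > 50000 nM is a limit and not a number.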